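Nitrophenyl in Place of Trimethoxyphenyl on the Ketone

This account rests on a few compounds, and the source may have more. Where it says the series, first, only, none or still open, it means among the compounds named here.

Measured so far:
compound 1 `COc1cc(C(=O)C2Sc3nnc(-c4cc(OC)c(OC)c(OC)c4)n3NC2c2ccco2)cc(OC)c1OC`: > 100000 nM
compound 2 `COc1cc(-c2nnc3n2NC(c2ccco2)C(C(=O)c2ccc(F)c(F)c2)S3)cc(OC)c1OC`: 73200 nM

In a functional assay on MCF7 cells (Homo sapiens) for cytotoxicity, read by MTT assay, with a stated time of 48 h (a lower number here means a stronger inhibitor, a higher number a weaker inhibitor), compound 1 gives only a limit, (the limit of > 100000 nM in this assay, at which 1 of the 2 values shown sits), so its true number is not known. Compound 2 gives 73200 nM in this assay. Within the data shown here, the single measured step, an at least 1.3-fold lower number from compound 1 to compound 2 (0.13 log units; that floor lies within the scatter), lies within the scatter. Compound 3 `COc1cc(-c2nnc3n2NC(c2ccco2)C(C(=O)c2ccc([N+](=O)[O-])cc2)S3)cc(OC)c1OC` differs from compound 1 by 4-nitrophenyl in place of 3,4,5-trimethoxyphenyl on a carbonyl carbon. Since this exchange replaces the same group at the same place as the measured step, a step of similar size is expected: an at least 1.2-fold lower number from compound 1 to compound 3 (0.09 log units; that floor lies within the scatter). For compound 3 the estimated value is 80000 nM, ranging from 30000 nM to 200000 nM.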

Compound 3, half-maximal inhibitory concentration: > 100000 nM
Compound 3 gave a limit, no number; the forecaster's own chance of this, stated with the estimate: 40%; at least 1.2-fold (0.09 log units) between middle value and limit.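

Like compound 1, compound 3 gives only a limit in this assay, > 100000 nM, so the step between those two cannot be read. Among these compounds, the one readable step, an at least 1.3-fold higher number from compound 2 to compound 3 (0.13 log units; that floor lies within the scatter), gives only a floor, so 4-nitrophenyl on the carbonyl carbon cannot be separated from 3,4-difluorophenyl. Swapping in this second group still yields no clear gain on the carbonyl carbon, and the readings crowd at one end: the limit of > 100000 nM in this assay, at which 2 of the 3 values shown sit.

Still open, from the compounds shown here alone, is whether a group such as an amine or a carboxylic acid on the carbonyl carbon's phenyl ring would give a number clearly lower than these.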